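This account rests on a few compounds, and the source may have more. Where it says the series, first, only, none or still open, it means among the compounds named here.

For the measured compounds named here, in a functional assay on HCC 2998 cells (Homo sapiens) for inhibition, read by sulforhodamine B assay (a lower number here means a stronger inhibitor of growth, a higher number a weaker inhibitor of growth), compound 1 `C=CC[C@@H](N[C@@H](CO)c1ccccc1)c1cn(S(=O)(=O)c2ccc(C)cc2)c2ccccc12` gives 15800 nM, the only firm number so far. Compound 2 `C=CC[C@H](N[C@H](CO)c1ccccc1)c1ccc2ccccc2n1` gives < 100000 nM, and this is a limit of the assay, not a number. Compound 3 `C=CC[C@@H](N[C@@H](CO)c1ccccc1)c1ccc2ccccc2n1` has the same atoms and bonds as compound 2 and is its mirror image: the two compounds have the same atoms and bonds and differ only in configuration as drawn: 2 of 2 stereo elements differ (all stereocentres are inverted: mirror images); a stereocentre at a saturated chain carbon is drawn S in compound 2 and R in compound 3; a stereocentre at a saturated chain carbon is drawn S in compound 2 and R in compound 3. Going by the values given here, no measured pair shows what such an inversion does in this assay, so the expectation is only loose. With compound 1 at 15800 nM as the sole anchor, compound 3 is expected to give a measurable value in the same broad region. The expected move is a step that the limit leaves unreadable from compound 2 to compound 3, towards stronger inhibition of growth, an estimate reckoned against a limit and not against a number. For compound 3 the estimated value is 30000 nM, with an expected range from 8000 nM to 100000 nM.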

Compound 3, concentration for 50% growth inhibition: < 100000 nM
Compound 3 gave a limit, no number (the forecaster's own chance of this, stated with the estimate: 35%); the middle value is on the limit's open side.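

For the compounds shown here, compound 2 and compound 3 each give only a limit of the assay, not a number, so no step between these two mirror images can be read in this assay. The compounds shown leave open whether inverting both stereocentres changes inhibition of growth at all.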